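Chloro in place of trifluoromethoxy: expected cytotoxicity of compound 3

This account rests on a few compounds, and the source may have more. Where it says the series, first, only, none or still open, it means among the compounds named here.

Compound 1 `FC(F)(F)Oc1ccc(-c2cc(COc3ccccc3-c3nc4ccccc4s3)on2)cc1` gives 23900 nM in a functional assay on A549 cells (Homo sapiens) for cytotoxicity, read by MTT assay, with a stated time of 24 h; on this read-out higher numbers stand for weaker inhibition and lower numbers for stronger inhibition. Among the compounds with values here, compound 2 `FC(F)(F)C(F)(F)C(F)(F)C(F)(F)C(F)(F)C(F)(F)C(F)(F)C(F)(F)CCn1cc(COc2ccccc2-c2nc3ccccc3s2)nn1` gives 13100 nM in this assay, and the two values lie within the scatter of each other, so neither stands apart on the numbers so far. Compound 3 `Clc1ccc(-c2cc(COc3ccccc3-c3nc4ccccc4s3)on2)cc1` differs from compound 1 by chloro in place of trifluoromethoxy on an aromatic carbon. Within the data shown here, no measured pair shows this change, so the expected step of a 1.2-fold lower number from compound 1 to compound 3 (0.08 log units; within the scatter) is small, in no clear direction and not beyond the scatter. Compound 3 is therefore estimated at 20000 nM in this assay, within 8000 nM to 50000 nM.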

Compound 3, half-maximal inhibitory concentration: 18800 nM
Compound 3: the middle estimate sits 1.1-fold (0.03 log units) above what was measured, within the range that was stated.
By their numbers in this assay, from the lowest: compounds 2, 3 and 1 (each within the scatter of the next).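

Replacing 4-(trifluoromethoxy)phenyl with 4-chlorophenyl in this assay gives a 1.3-fold lower number from compound 1 to compound 3 (0.10 log units; within the scatter) as the first step read at this position. On this aromatic carbon, para to a large group, the read-out does not separate chloro from trifluoromethoxy, even though one heavy atom enters where five leave. No evidence is available that bears on this result.

The compounds shown leave open whether an amine or a carboxylic acid at this position would move the number beyond the scatter.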